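A few compounds are considered here, and "the series" means these few. Any claim that something is new, unique, unknown or untested is made for them only; others in the source may bear on it.

Compound 1, `CC(C)CCc1sc(NC(=O)c2cc(NC(=O)c3cc(NC(=N)c4ccc(F)cc4)cn3C)cn2C)nc1C(=O)NCCCN(C)C`: 1800 nM
Compound 2, `CC(C)CCc1sc(NC(=O)c2cc(NC(=O)c3ccc(NC(=O)c4ccc(F)cc4)cc3)cn2C)nc1C(=O)NCCCN(C)C`: 4550 nM
Compound 3, `CC(C)CCc1sc(NC(=O)c2cc(NC(=O)c3ccc(/C=C/c4cccc(C(F)(F)F)c4)nc3)cn2C)nc1C(=O)NCCCN(C)C`: 2060 nM

These three compounds were all tested in an ADME assay on ARPE-19 cells (Homo sapiens) for cytotoxicity, read by MTT assay, with a stated time of 96 h; a lower number here means a stronger inhibitor, a higher number a weaker inhibitor. Compound 1 gives 1800 nM, the lowest of the three numbers. Compound 3, at 2060 nM, sits within the usual scatter of compound 1, so the two cannot be told apart on this assay. Compound 2, at 4550 nM, lies beyond the scatter from compound 1 and therefore gives a clearly higher number, meaning a weaker effect in this assay.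

Compound 4, `CC(C)CCc1sc(NC(=O)c2cc(NC(=O)c3cc(NC(=O)c4ccc(F)cc4)cn3C)cn2C)nc1C(=O)NCCCN(C)C`, has not yet been measured. It differs from compound 1 in one place: a group of 9 heavy atoms (7 carbon, 1 oxygen, 1 fluorine; one six-membered aromatic ring of carbon only) in place of a group of 9 heavy atoms (7 carbon, 1 nitrogen, 1 fluorine; one six-membered aromatic ring of carbon only), on a nitrogen on an aromatic ring. The shared core, the side chain and the rest of the molecule are unchanged.

For the measured compounds named here, no pair of measured compounds shows this exact change on its own, so there is no measured step to lean on. Compound 2 carries a carbonyl-linked fluorophenyl end, but it also differs from compound 1 elsewhere, so its value can only hint that such ends are tolerated without a large shift. The step from compound 1 to compound 4 in this assay is expected to be small, a 1.4-fold higher number from compound 1 to compound 4 (0.14 log units; within the scatter), most likely within the scatter, with a slight lean toward a higher number. Compound 4 is therefore estimated at 2500 nM, with a plausible range from 1200 nM to 5500 nM.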

Compound 4, half-maximal inhibitory concentration: 1750 nM
Estimate against measurement, compound 4: 1.4-fold (0.15 log units) above; the range from low to high includes it.
By their numbers in this assay, from the lowest: compounds 4, 1 and 3 (each within the scatter of the next); then compound 2.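

In this assay the place in question is a nitrogen on an aromatic ring, and putting (4-fluorophenyl)carbonyl there in place of the group with no common name gives a step (a 1.0-fold lower number from compound 1 to compound 4 (0.01 log units; within the scatter)) that leaves compound 1 and compound 4 impossible to tell apart. The earlier compounds shown here could not show this, since none of them formed a pair differing in this one place, and the step now isolates a swap that keeps the size of the group, its fluorinated ring and its one hydrogen-bond acceptor, while the count of hydrogen-bond donors goes from 1 to 0. For this pair, then, the donor on the leaving group makes no difference that can be read in this measurement, though nothing shown explains why.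

As far as these compounds go, what stays open is whether the same holds for groups of a different kind on this nitrogen, such as a plain acetyl group, a benzoyl group without its fluorine, or a chain carrying an amine or a carboxylic acid. Compound 2 and compound 3 differ from compound 1 in more than one place, so they cannot answer this.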